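A few compounds are considered here, and "the series" means these few. Any claim that something is new, unique, unknown or untested is made for them only; others in the source may bear on it.

Compound 1 `C=CCOc1ccc2c(=O)c(-c3cc(OC)c(OC)cc3OC)coc2c1` gives > 10000 nM (a limit of the assay, not a number)
Compound 2 `COc1cc(OC)c(-c2coc3cc(OCc4ccccc4F)ccc3c2=O)cc1OC` gives 4300 nM (lowest number shown)
Compound 3 `COc1cc(OC)c(-c2coc3cc(OCc4ccccc4C)ccc3c2=O)cc1OC` gives 4830 nM (nearest number to compound 2)

These results come from a functional assay on HUVEC cells (Homo sapiens) for antiproliferative activity, read by MTT assay, with a stated time of 24 h; a higher number here means a weaker inhibitor, a lower number a stronger inhibitor (a test of how strongly each compound holds back cell growth). Compound 2 sits at the low end of the numbers, but its nearest neighbour is level with it within the scatter (a 1.1-fold higher number from compound 2 to compound 3 (0.05 log units; within the scatter)). Compound 4 `COc1cc(OC)c(-c2coc3cc(OCc4cccc(F)c4)ccc3c2=O)cc1OC` has not yet been measured. It differs from compound 2 only in where the fluorine sits (3-fluorophenyl in place of 2-fluorophenyl on a saturated chain carbon bound to an oxygen on an aromatic ring), and the two have the same atoms, joined differently.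

Among the compounds with values here, no measured step makes this exact change, so the evidence is indirect. Two steps replace vinyl with a substituted phenyl and lower the number beyond the scatter (an at least 2.3-fold lower number from compound 1 to compound 2 (0.36 log units; beyond the scatter); an at least 2.0-fold lower number from compound 1 to compound 3 (0.31 log units; beyond the scatter)). Compound 4 keeps a substituted phenyl at that place, so the gain seen for compound 2 should largely remain. The closest guide is the swap of fluoro for methyl (a 1.1-fold higher number from compound 2 to compound 3 (0.05 log units; within the scatter)), which stayed within the scatter. A shift of the fluorine is therefore expected to cause little change, and the estimated step is small (a 1.0-fold higher number from compound 2 to compound 4 (0.02 log units; within the scatter)). Compound 4 is estimated at 4500 nM (expected range 2200 nM to 9000 nM).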

Compound 4, half-maximal inhibitory concentration: 5300 nM
For compound 4 the middle estimate is 1.2-fold (0.07 log units) below the measured one; the measured number falls inside the stated range.
By their numbers in this assay, from the lowest: compounds 2, 3 and 4 (each within the scatter of the next). At a limit, above all of these: compound 1.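

In this assay, the place of the fluorine on this ring makes no difference that can be read, as 3-fluorophenyl in place of 2-fluorophenyl gives a 1.2-fold higher number from compound 2 to compound 4 (0.09 log units; within the scatter). The new compound also cannot be told apart from the methyl-bearing one, with a 1.1-fold higher number from compound 3 to compound 4 (0.04 log units; within the scatter), so at this place on the saturated chain carbon bound to an oxygen, the three substituted phenyl groups shown behave alike in this test. The step from vinyl is less clear this time, with an at least 1.8-fold lower number from compound 1 to compound 4 (0.27 log units; that floor lies within the scatter), and so, unlike the two earlier steps from vinyl, it does not on its own show a gain, since the value for compound 1 is a limit and not a number: the limit of > 10000 nM in this assay, at which 1 of the 4 values shown sits.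

The compounds shown leave open whether any group at this place could move the number well beyond the scatter, for instance a plain phenyl, a phenyl carrying an amine or a carboxylic acid, or a longer chain between the oxygen and the ring. They also leave open whether the three-way match seen here would hold for other groups on the ring, such as chloro or methoxy.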